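Trimming the Ether Side Chain of Compound 1

The source may hold more compounds than are shown below. What is called first, only, known or untested is meant among the compounds shown, and "the series" means these compounds.

Compound 1 `COCCOc1cc2oc(=O)n(CCC(=O)O)c2cc1Cl`: 50100 nM
Compound 2 `C[C@@H](Oc1cc2oc(=O)n(CCC(=O)O)c2cc1Cl)c1ccc(F)cn1`: 25.1 nM
Compound 3 `Cc1ccc([C@@H](C)Oc2cc3oc(=O)n(CCC(=O)O)c3cc2Cl)nc1`: 6.31 nM

Of the compounds shown here, three sharing one core have been measured in an assay on HEK293 cells for inhibition of kynurenine 3-monooxygenase (Homo sapiens), read by LC-MS, with a stated time of 20 h; a lower number here means a stronger inhibitor, a higher number a weaker inhibitor. Compound 1 stands highest of the three numbers: compound 2 and compound 3 both give far lower numbers, so compound 1 is the weakest inhibitor of the set. Going by the values given here, the only measured single step, a 4.0-fold lower number from compound 2 to compound 3 (0.60 log units; beyond the scatter), concerns methyl in place of fluoro on an aromatic carbon and says nothing about the ether chain that is changed here.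

Compound 4 `COc1cc2oc(=O)n(CCC(=O)O)c2cc1Cl` differs from compound 1 by hydrogen in place of methoxymethyl on a saturated chain carbon bound to an oxygen on an aromatic ring. Among the compounds with values here, no measured step covers the removal of methoxymethyl from this chain. What the data do show is that the much larger aryl-bearing ethers of compound 2 and compound 3 give far lower numbers than compound 1, while the small 2-methoxyethoxy of compound 1 sits at the top. Cutting the chain further is therefore expected to move the number little, and if anything upward, so the estimated step is a 1.8-fold higher number from compound 1 to compound 4 (0.25 log units; within the scatter). For compound 4 the expected value is 90000 nM, within 25000 nM to 300000 nM.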

Compound 4, half-maximal inhibitory concentration: 5010 nM
Compound 4: middle estimate off by 18-fold (1.25 log units), on the high side, outside the stated range (below it).
By their numbers in this assay, from the lowest: compound 3; then compound 2; then compound 4; then compound 1.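

Going by these compounds alone, the step of a 10-fold lower number from compound 1 to compound 4 (1.00 log units; beyond the scatter) in this assay shows that this ether chain can be cut from 2-methoxyethoxy to methoxy with a gain in inhibition, something the earlier compounds could not show, as their only single step lay on an aromatic carbon. It also shows that chain size alone does not order the numbers at this position: compound 4 carries the shortest ether of the set yet gives a lower number than compound 1, while the larger aryl-bearing ethers of compound 2 and compound 3 give lower numbers than compound 4. No measurement at hand accounts for this step.

On these data alone, it remains open whether an ethoxy group would give a number closer to compound 4 or to compound 1. Equally open, as far as these compounds go, is how a chain ending in an amine or a carboxylic acid would compare at this position.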